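Benzylamino for piperidin-1-yl on the propyl chain

This account rests on a few compounds, and the source may have more. Where it says the series, first, only, none or still open, it means among the compounds named here.

In a functional assay on MDA-MB-231 cells (Homo sapiens) for antiproliferative activity, read by MTT assay, with a stated time of 24 h (on this read-out higher numbers stand for weaker inhibition and lower numbers for stronger inhibition), compound 1 `CCCCc1oc2ccccc2c1C(=O)c1ccc(OCC(=O)N2CCOCC2)cc1` gives > 50000 nM, which is a limit of the assay and not a number. Compound 2 `CCCCc1oc2ccccc2c1C(=O)c1ccc(OCC(=O)Nc2cccc(OC)c2)cc1` gives > 50000 nM, again only a limit. Among the compounds with values here, compound 3 `CCCCc1oc2ccccc2c1C(=O)c1cc(I)c(OCCCN2CCCCC2)c(I)c1` gives 15700 nM, the only true number among the three.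

Compound 4 `CCCCc1oc2ccccc2c1C(=O)c1cc(I)c(OCCCNCc2ccccc2)c(I)c1` carries benzylamino in place of piperidin-1-yl on a saturated chain carbon, three bonds along the chain from an oxygen on an aromatic ring. Within the data shown here, the one measured step, a step that the two limits leave unreadable from compound 1 to compound 2, concerns a group on a carbonyl carbon, and its size cannot be read, so it offers no guide to this change. The expectation therefore rests on compound 3 alone, at 15700 nM, and no change beyond the scatter is expected in this assay. The expected step is a 1.2-fold lower number from compound 3 to compound 4 (0.08 log units; within the scatter). Compound 4 is estimated at 13000 nM, within an expected range from 5000 nM to 40000 nM.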

Compound 4, half-maximal inhibitory concentration: 11600 nM
Compound 4: the middle estimate sits 1.1-fold (0.05 log units) above what was measured, and the stated range covers the measured number.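

Within the data shown here, this is the first step in this assay whose size can be read, and it is a 1.4-fold lower number from compound 3 to compound 4 (0.13 log units; within the scatter). At the end of the propyl chain, then, the piperidin-1-yl group and the benzylamino group are not told apart by this read-out. That holds even though the swap replaces a six-membered non-aromatic ring with a six-membered aromatic ring and adds a hydrogen-bond donor, so this position accepts at least this one change with no shift beyond the scatter.

Going by these compounds, it remains open whether the chain nitrogen matters at all, which a hydroxyl group or a dimethylamino group at the chain end would test, and whether a longer chain such as 4-(piperidin-1-yl)butyl would read differently. The numbers available for comparison are also few: the limit of > 50000 nM in this assay, at which 2 of the 4 values shown sit.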